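The source may report more compounds than this note shows. Statements on the series, on what has been measured and on what is new or still open speak of the compounds shown alone.

Among the compounds with values here, in an ADME assay on HEK293 cells (Homo sapiens) for inhibition, read by MTT assay, with stated times of 18 h and 4 h (on this read-out lower numbers stand for stronger inhibition and higher numbers for weaker inhibition), compound 1 `CCCCCCCCOP(=O)(O)OCCSC(=S)N1CCCC1` gives 28300 nM, the only exact number available, so it serves as the reference point here. Compound 2 `CCCCCCCCCCOP(=O)(O)OCCSC(=S)N1CCCC1` reads > 100000 nM, which is a limit of the assay and not a number. Compound 3 `CCCCCCCCCCCCCCCCOP(=O)(O)OCCSC(=S)N1CCN(C)CC1` reads > 100000 nM, which is also a limit. Much of the picture therefore rests on (the limit of > 100000 nM in this assay, at which 2 of the 3 values shown sit).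

Compound 4 `CCCCCCCCOP(=O)(O)OCCSC(=S)N1CCCCCC1` has not yet been measured. It differs from compound 1 in one place: azepan-1-yl in place of pyrrolidin-1-yl on a thiocarbonyl carbon. In plain words, azepan-1-yl, a seven-membered ring, stands in place of pyrrolidin-1-yl, a five-membered ring, on a thiocarbonyl carbon.

Within the data shown here, no measured step makes this same ring change, so the closest guide is a change elsewhere in the molecule that also adds carbon atoms. As far as these compounds go, that guide is an at least 3.5-fold higher number from compound 1 to compound 2 (0.54 log units; beyond the scatter), a step beyond the scatter whose true size remains open, since it ends at a limit. It offers only a loose parallel, so a cautious expectation is a modest shift towards weaker inhibition in this assay. The expected change is a 1.4-fold higher number from compound 1 to compound 4 (0.15 log units; within the scatter). For compound 4 the estimated value is 40000 nM, with an expected range from 14000 nM to 100000 nM.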

Compound 4, half-maximal inhibitory concentration: > 100000 nM
Compound 4 ended at the assay's limit; the forecaster's own chance of this, stated with the estimate: 30%; middle value at least 2.5-fold (0.39 log units) away from the limit.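

In this assay, within the data shown here, azepan-1-yl in place of pyrrolidin-1-yl on a thiocarbonyl carbon gives an at least 3.5-fold higher number from compound 1 to compound 4 (0.54 log units; beyond the scatter), the first measured step at this position, and it lies beyond the scatter. The earlier readable step came from a change in the chain, whereas this one shows that a change in the ring on the thiocarbonyl carbon alone, with the rest of the molecule unchanged, is enough to move the read-out towards weaker inhibition. As far as these compounds go, compound 4 reads > 100000 nM, which is a limit of the assay and not a number, so the true size of the step stays open.

The compounds shown leave open whether a piperidin-1-yl ring or an open-chain amine such as diethylamino at this same place would give an exact number, which could show how the read-out follows the group on the thiocarbonyl carbon. Any such comparison still hangs on compound 1 as the single exact reference, and the rest of the set sits at one ceiling: the limit of > 100000 nM in this assay, at which 3 of the 4 values shown sit.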